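The compounds below may be only part of what the source reports. "The series", "measured", "known", "first", "only" and "open" are said of these compounds alone.

Measured so far:
- compound 1 `CN(CCCN1CCCCC1)c1ccc(C(=O)N2CCc3ccc(OS(N)(=O)=O)cc3C2)cc1` — 17.4%
- compound 2 `NS(=O)(=O)Oc1ccc2c(c1)CN(C(=O)c1cccc(N(Cc3ccccc3)Cc3ccco3)c1)CC2` — 27.5%

Of the compounds shown here, two share the same core and have been tested in an assay on HEK293 cells for inhibition of Steryl-sulfatase (Homo sapiens), tested at 0.1 uM; on this read-out lower numbers stand for a weaker effect and higher numbers for a stronger effect at the one concentration tested. Compound 1 `CN(CCCN1CCCCC1)c1ccc(C(=O)N2CCc3ccc(OS(N)(=O)=O)cc3C2)cc1` gives 17.4%, the lowest of the two numbers. Its nearest neighbour is compound 2 `NS(=O)(=O)Oc1ccc2c(c1)CN(C(=O)c1cccc(N(Cc3ccccc3)Cc3ccco3)c1)CC2`, which in this assay gives 27.5%, a number that lies higher by an amount beyond the usual scatter of repeated measurements.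

The next compound, compound 3 `CCN(Cc1ccncc1)c1ccc(C(=O)N2CCc3ccc(OS(N)(=O)=O)cc3C2)cc1`, has not yet been measured. It differs from compound 1 in one place: ethyl((pyridin-4-yl)methyl)amino in place of methyl(3-(piperidin-1-yl)propyl)amino on an aromatic carbon. Going by the values given here, no measured pair with this change is available, so the expectation rests on the two numbers alone. Both sit at the weak end of this assay, and the step of a number 4.6 percentage points higher from compound 1 to compound 3 (within the scatter) is expected to be small, within the usual scatter, in either direction. Compound 3 is therefore expected to give 22%, with a range from 5% to 45%.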

Compound 3, a percentage reported as inhibition, at one concentration (the size of the read-out at that concentration, not a potency): 47%
Estimate against measurement, compound 3: 25 percentage points below; the whole stated range lies below it.
By their numbers in this assay, from the lowest: compound 1; then compound 2; then compound 3.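

This position, on an aromatic carbon para to a large group, is not indifferent in this assay: ethyl((pyridin-4-yl)methyl)amino in place of methyl(3-(piperidin-1-yl)propyl)amino gives a number 29.6 percentage points higher from compound 1 to compound 3 (beyond the scatter). A clear change in the read-out therefore appears between two groups of nearly equal heavy-atom count, with the same count of hydrogen-bond acceptors, where one ring is aromatic and the other is not. Nothing measured here accounts for this step.

From the compounds shown here alone, the swap alters the ring, the chain joining it to the nitrogen, and methyl to ethyl all at once, so which of these parts carries the step remains open. Also open, going by these compounds, is how a morpholine ring or a pyridin-3-yl ring would read at this position.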